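The compounds below may be only part of what the source reports. "The series", "measured", "known", "first", "only" and "open" are said of these compounds alone.

For the measured compounds named here, in an ADME assay on HEK-293T cells (Homo sapiens) for cytotoxicity, read by CCK-8 assay, with a stated time of 48 h (on this read-out lower numbers stand for stronger inhibition and higher numbers for weaker inhibition), compound 1 `O=C(Nc1ccc(F)cc1)N1CCN(S(=O)(=O)c2sccc2-c2ccccc2Oc2ccc(O)c(O)c2)CC1` gives 15500 nM, the only exact number so far. Compound 2 `O=[N+]([O-])c1ccc(NC(=S)NCCNS(=O)(=O)c2ccc(-c3ccccc3OCc3cccc(O)c3)s2)cc1` reads > 20000 nM, which is a limit of the assay and not a number. Compound 3 `O=C(Nc1ccc([N+](=O)[O-])cc1)N1CCN(S(=O)(=O)c2sccc2-c2ccccc2Oc2ccc(O)c(O)c2)CC1` keeps the core of compound 1 and swaps a single group, 4-fluorophenyl to 4-nitrophenyl: nitro in place of fluoro on an aromatic carbon. Going by the values given here, no measured pair shows what this swap does, so with compound 1 at 15500 nM as the only anchor, no step beyond the usual scatter is expected in this assay. For compound 3 the expected value is 14000 nM, with an estimated range from 6000 nM to 20000 nM.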

Compound 3, half-maximal inhibitory concentration: > 20000 nM
Compound 3 was reported as a limit; the forecaster's own chance of this, stated with the estimate: 25%; middle value at least 1.4-fold (0.15 log units) from the limit.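

In this assay, the reading for compound 3 is a limit of the assay and not a number. Nitro in place of fluoro on this aromatic carbon gives an at least 1.2-fold higher number from compound 1 to compound 3 (0.11 log units; that floor lies within the scatter), so the swap brings no lower number, although that floor alone does not separate the two compounds. The true size of the step cannot be read because the measurement stops there: the limit of > 20000 nM in this assay, at which 2 of the 3 values shown sit.

Going by these compounds, how far the number would actually rise with nitro remains open. So does whether an amine or a carboxylic acid on the same aromatic carbon would bring the number down.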